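This account rests on a few compounds, and the source may have more. Where it says the series, first, only, none or still open, it means among the compounds named here.

Compound 1 `CCc1nc(-c2cnc(OC)nc2OC)c(CC)nc1NC(CC)CC`: 17.2 nM
Compound 2 `CCc1nc(-c2ccc(Cl)cc2Cl)c(CC)nc1CC(CC)CC`: 68 nM

Both compounds were tested in an assay on IMR-32 cells for displacement of a labelled ligand from corticotropin-releasing factor receptor 1 (Homo sapiens), read by scintillation counting, with a stated time of 2 h; a lower number here means a stronger inhibitor, a higher number a weaker inhibitor. Compound 2 has the highest of the two numbers; its nearest neighbour, compound 1, gives a lower number, and that gap lies beyond the scatter. Compound 3 `CCc1nc(-c2ccc(Cl)cc2Cl)c(CC)nc1NC(C)CN(C)C` has not been measured yet. It differs from compound 2 in one place: (1-((dimethylamino)methyl)ethyl)amino in place of 2-ethylbutyl on an aromatic carbon. For the measured compounds named here, no step between two measured compounds covers this kind of change, so its size cannot be read off directly. Compound 1, whose side chain is also joined through an amino group, gives 17.2 nM in this assay, and so only a small move towards a lower number, within the usual scatter, is expected. The expected step is a 1.7-fold lower number from compound 2 to compound 3 (0.23 log units; within the scatter). Compound 3 is estimated at 40 nM, with a range from 10 nM to 160 nM.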

Compound 3, inhibition constant: 489 nM
Compound 3: middle estimate off by 12-fold (1.09 log units), on the low side; the whole stated range lies below it.
By their numbers in this assay, from the lowest: compound 1; then compound 2; then compound 3.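

In this assay, putting (1-((dimethylamino)methyl)ethyl)amino in place of 2-ethylbutyl gives a 7.2-fold higher number from compound 2 to compound 3 (0.86 log units; beyond the scatter), which shows that this position, para to a 2,4-dichlorophenyl group, is sensitive to the group it carries. The change is not a single one: the entering group has 2 nitrogen, 1 hydrogen-bond donor and 2 hydrogen-bond acceptors, whereas the leaving group has none of these. No measurement here explains why the number rises.

The shown compounds leave open whether the step comes from the amino link on the aromatic carbon or from the dimethylamino end of the chain. On the core of compound 2, an all-carbon chain joined through an amino group, or a chain ending in a methoxy group, would help separate these two parts.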